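Cycloalkyl variation at the amide nitrogen: cytotoxicity notes

The source may report more compounds than this note shows. Statements on the series, on what has been measured and on what is new or still open speak of the compounds shown alone.

Compound 1 `CC(C)(C)C(=O)N(CCCCCCN1C[C@H](O)[C@@H](O)[C@H](O)[C@H]1CO)C1CCCCC1` gives in an ADME assay on BHK cells (Mesocricetus auratus) for cytotoxicity, read by MTT assay (a higher number here means that more compound is tolerated, a lower number that less compound is tolerated), the value > 500000 nM.
Compound 2 `CC(C)(C)C(=O)N(CCCCCCN1C[C@H](O)[C@@H](O)[C@H](O)[C@H]1CO)C1CCCC1` gives in this assay the value > 500000 nM.

Both values are limits of this assay, as noted in the limit of > 500000 nM in this assay, at which 2 of the 2 values shown sit. Compound 2 therefore stands only at a limit in this assay. The step that the two limits leave unreadable from compound 1 to compound 2 bears on the next change but offers no readable size. Compound 3 `CC(C)(C)C(=O)N(CCCCCCN1C[C@H](O)[C@@H](O)[C@H](O)[C@H]1CO)C1CCCCCCC1` carries cyclooctyl in place of cyclopentyl on an amide-type nitrogen. With only an unreadable step as guide, no change beyond the scatter is expected for compound 3, and its value in this assay is estimated at 500000 nM (range 200000 nM to 1000000 nM), meaning an expected step of a number no higher from compound 2 to compound 3 (the limit leaves the size open).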

Compound 3, half-maximal cytotoxic concentration: 208000 nM
Beside the measured number, compound 3's estimate is 2.4-fold (0.38 log units) above it, within the range that was stated.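

With cyclooctyl, this position gives its first readable change in this assay: cyclooctyl in place of cyclopentyl gives an at least 2.4-fold lower number from compound 2 to compound 3 (0.38 log units; beyond the scatter), and cyclooctyl in place of cyclohexyl gives an at least 2.4-fold lower number from compound 1 to compound 3 (0.38 log units; beyond the scatter). The cycloalkyl group on this amide-type nitrogen can therefore shift the tolerated concentration, which compounds 1 and 2 alone could not show. Both steps are only lower bounds on size because compounds 1 and 2 rest on a limit: the limit of > 500000 nM in this assay, at which 2 of the 3 values shown sit.

From the compounds shown here alone, whether the number falls gradually with ring size or only at the largest ring stays open. A cycloheptyl group or an open-chain hexyl group on this nitrogen would bear on that question.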